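Benzyl Carbamate Next in a Selenocyanate Carbamate Series

The source may report more compounds than this note shows. Statements on the series, on what has been measured and on what is new or still open speak of the compounds shown alone.

Measured so far:
compound 1, `CCCCOC(=O)Nc1ccc([Se]C#N)cc1`, in a functional assay on PC-3 cells (Homo sapiens) for cytotoxicity, read by MTT assay, with a stated time of 72 h (a higher number here means a weaker inhibitor of growth, a lower number a stronger inhibitor of growth), gives 40800 nM
compound 2, `C=CCOC(=O)Nc1ccc([Se]C#N)cc1`, in this assay gives 44700 nM
compound 3, `CCOC(=O)Nc1ccc([Se]C#N)cc1`, in this assay gives 39200 nM

Compound 3 has the lowest of the three numbers, but its gaps to the other two are within the scatter, so no order among them can be claimed. Compound 4, `N#C[Se]c1ccc(NC(=O)OCc2ccccc2)cc1`, differs from compound 3 by phenyl in place of methyl on a saturated chain carbon bound to an oxygen next to a carbonyl group. The steps bearing on this are the three ester-side changes already seen: a 1.1-fold higher number from compound 1 to compound 2 (0.04 log units; within the scatter), a 1.0-fold lower number from compound 1 to compound 3 (0.02 log units; within the scatter) and a 1.1-fold lower number from compound 2 to compound 3 (0.06 log units; within the scatter), all within the scatter. On this basis the expected step of a 1.0-fold lower number from compound 3 to compound 4 (0.01 log units; within the scatter) in this assay is none beyond the scatter, though phenyl is a larger change than any tried so far. Compound 4 is therefore estimated at 38000 nM, with a range from 15000 nM to 90000 nM.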

Compound 4, concentration for total growth inhibition: 27800 nM
Compound 4: the middle estimate sits 1.4-fold (0.14 log units) above what was measured; the measured number falls inside the stated range.
By their numbers in this assay, from the lowest: compounds 4, 3, 1 and 2 (each within the scatter of the next).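

In this assay phenyl on this saturated chain carbon brings a 1.4-fold lower number from compound 3 to compound 4 (0.15 log units; within the scatter) and a 1.6-fold lower number from compound 2 to compound 4 (0.21 log units; within the scatter) and also a 1.5-fold lower number from compound 1 to compound 4 (0.17 log units; within the scatter) so even an aromatic ring in this place gives no step beyond the scatter. The position thus accepts phenyl as well as the open chains seen earlier, with no order among the four compounds. Nothing available explains these numbers.

Going by these compounds, whether a carboxylic acid or an amine at this position, or a methoxy group on the phenyl ring, would move the number beyond the scatter remains open.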